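Moving the fluorine on the phenyl ring

The source may report more compounds than this note shows. Statements on the series, on what has been measured and on what is new or still open speak of the compounds shown alone.

Compound 1 `CCCn1c(=O)[nH]c2nc(-c3ccc(S(=O)(=O)N4CCN(c5cccc(Cl)c5)CC4)cc3)[nH]c2c1=O` carries a 3-chlorophenyl group on the ring nitrogen, and in an assay on CHO cells for displacement of a labelled ligand from adenosine receptor A3 (Homo sapiens), read by scintillation counting, with a stated time of 45 min, in the presence of a further agent that is not named here (a lower number here means a stronger inhibitor, a higher number a weaker inhibitor), compound 1 gives 53.5 nM. Compound 2 `CCCn1c(=O)[nH]c2nc(-c3ccc(S(=O)(=O)N4CCN(c5ccccc5F)CC4)cc3)[nH]c2c1=O` bears a 2-fluorophenyl group in that place. In this assay compound 2 gives > 1000 nM, which is a limit of the measurement rather than a number (the limit of > 1000 nM in this assay, at which 1 of the 2 values shown sits). Compound 2 therefore stands at the weak end of the two compounds shown, known only as a limit. The measured step of an at least 18-fold higher number from compound 1 to compound 2 (1.27 log units; beyond the scatter) is large, but it changes both the halogen and its group name at once. Compound 3 `CCCn1c(=O)[nH]c2nc(-c3ccc(S(=O)(=O)N4CCN(c5cccc(F)c5)CC4)cc3)[nH]c2c1=O` differs from compound 2 only by 3-fluorophenyl in place of 2-fluorophenyl on an amine nitrogen in a ring. Because compound 1 gives 53.5 nM with a 3-chlorophenyl group, compound 3 is expected to bind more strongly than compound 2, with an expected step of an at least 4.0-fold lower number from compound 2 to compound 3 (0.60 log units; beyond the scatter). For compound 3 the estimated value is 250 nM, expected to lie between 60 nM and 1000 nM.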

Compound 3, inhibition constant: > 1000 nM
Compound 3 gave a limit, no number (the forecaster's own chance of this, stated with the estimate: 25%); at least 4.0-fold (0.60 log units) between middle value and limit.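

In this assay compound 3 gives > 1000 nM, which is a limit and not a number. The change of fluoro in place of chloro on an aromatic carbon gives an at least 18-fold higher number from compound 1 to compound 3 (1.27 log units; beyond the scatter), so here the halogen swap alone, with no move to the 2-fluorophenyl group, is enough for a large loss of binding. Neither fluorophenyl compound can be ranked against the other, and the step between them cannot be read: the limit of > 1000 nM in this assay, at which 2 of the 3 values shown sit.

Going by these compounds, how much weaker these two fluorophenyl compounds really are remains open. So does the effect of moving the chlorine, which a 2-chlorophenyl group on the same amine nitrogen would show, and whether a 3-bromophenyl or 3-methylphenyl group there would bind like the 3-chlorophenyl group of compound 1.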